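Styryl in place of substituted phenyl on the hydrazone carbon

The source may hold more compounds than are shown below. What is called first, only, known or untested is meant among the compounds shown, and "the series" means these compounds.

Of the compounds shown here, three that share one core have been measured in a functional assay on MCF7 cells (Homo sapiens) for inhibition, read by MTT assay, with a stated time of 48 h; a lower number here means a stronger inhibitor, a higher number a weaker inhibitor. Compound 1 `O=C(CSc1nnc(-c2ccncc2)n1-c1ccccc1)N/N=C/c1ccc(Br)cc1` gives 7040 nM. Compound 2 `O=C(CSc1nnc(-c2ccncc2)n1-c1ccccc1)N/N=C/c1ccc(F)cc1`, which carries fluoro in place of bromo on an aromatic carbon, gives 12300 nM; the step of a 1.7-fold higher number from compound 1 to compound 2 (0.24 log units; within the scatter) lies within the scatter. Compound 3 `O=C(CSc1nnc(-c2ccncc2)n1-c1ccccc1)N/N=C/c1cc(Br)ccc1O` gives 6460 nM in this assay; the steps of a 1.1-fold lower number from compound 1 to compound 3 (0.04 log units; within the scatter) and a 1.9-fold lower number from compound 2 to compound 3 (0.28 log units; within the scatter) are likewise within the scatter. Compound 3 thus holds the lowest of the three numbers, yet it is not separated from compound 1 or from compound 2 beyond the scatter.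

Compound 4 `O=C(CSc1nnc(-c2ccncc2)n1-c1ccccc1)N/N=C/C=C/c1ccccc1` has not yet been measured. Its difference from compound 3 is 2-phenylethenyl in place of 5-bromo-2-hydroxyphenyl on a carbon with a double bond to nitrogen. Going by the values given here, none of the measured steps exchanges the ring itself for a group with a double bond outside aromatic rings; they only alter what sits on that ring, and every one of them stayed within the scatter. Among the compounds with values here, no measured step therefore bears directly on this exchange, and the numbers seen so far sit close together. Within the data shown here, compound 4 is expected to give a number near those of the measured compounds, with a step of a 1.2-fold higher number from compound 3 to compound 4 (0.09 log units; within the scatter) that is not expected to pass beyond the scatter, while the range is kept wide since no measured step tests this kind of change. The estimate for compound 4 is 8000 nM, with a range from 3000 nM to 25000 nM.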

Compound 4, half-maximal inhibitory concentration: 11200 nM
Beside the measured number, compound 4's estimate is 1.4-fold (0.15 log units) below it, within the range that was stated.
By their numbers in this assay, from the lowest: compounds 3, 1, 4 and 2 (each within the scatter of the next).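

In this assay, going by these compounds alone, the earlier steps altered only what sits on the phenyl ring, whereas this one places 2-phenylethenyl on the carbon with a double bond to nitrogen, bringing in a double bond outside aromatic rings, and the result is not separated from any of the three phenyl compounds: a 1.7-fold higher number from compound 3 to compound 4 (0.24 log units; within the scatter) and a 1.1-fold lower number from compound 2 to compound 4 (0.04 log units; within the scatter) and also a 1.6-fold higher number from compound 1 to compound 4 (0.20 log units; within the scatter). Compound 4 has neither the bromine nor the hydrogen-bond donor and acceptor counted on the 5-bromo-2-hydroxyphenyl group of compound 3, so these compounds show no measurable need for those atoms, or for a phenyl ring attached directly to this carbon. Nothing measured here accounts for this result.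

On these data alone, all four compounds carry a six-membered aromatic ring of carbon only in this group, so it remains open whether an amine, a carboxylic acid or a longer saturated carbon chain here would move the number beyond the scatter. As far as these compounds go, it is also open whether a bromo or hydroxy group on the ring of 2-phenylethenyl would do so.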